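This account rests on a few compounds, and the source may have more. Where it says the series, first, only, none or still open, it means among the compounds named here.

Of the compounds shown here, three built on a shared core have been tested in a functional assay on SNB-19 cells (Homo sapiens) for inhibition, read by sulforhodamine B assay, with a stated time of 48 h, tested at 10 uM; on this read-out higher numbers stand for more inhibition at the one concentration tested (going by the name of the read-out) and lower numbers for less inhibition. Compound 1 `Brc1cn2ccnc2c(-c2ccc3ncn(C4CCCCC4)c3c2)n1` gives 8.09%. Compound 2 `COc1ccc(-c2cn3ccnc3c(-c3ccc4ncn(C5CCCCC5)c4c3)n2)cc1` gives 68.4%, and compound 3 `c1cn2cc(-c3ccsc3)nc(-c3ccc4ncn(C5CCCCC5)c4c3)c2n1` gives 0.39%. Compound 3 has the smallest of the three numbers, though its gap to compound 1 lies within the scatter, while compound 2 stands far above it. Among the measured steps, a number 60.3 percentage points higher from compound 1 to compound 2 (beyond the scatter), whereas a number 7.7 percentage points lower from compound 1 to compound 3 (within the scatter).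

Compound 4 `COc1ccccc1-c1cn2ccnc2c(-c2ccc3ncn(C4CCCCC4)c3c2)n1` differs from compound 3 in one place: 2-methoxyphenyl in place of thiophen-3-yl on an aromatic carbon. The step that bears on this is the one where a methoxyphenyl ring replaced the thiophen-3-yl ring: a number 68 percentage points lower from compound 2 to compound 3 (beyond the scatter) read in reverse. Compound 4 again carries a methoxyphenyl ring, though as 2-methoxyphenyl rather than 4-methoxyphenyl, so a large rise is expected in this assay, with some doubt whether it reaches the level of compound 2. Compound 4 is therefore estimated at 40%, with a range from 5% to 75%, meaning an expected step of a number 39.6 percentage points higher from compound 3 to compound 4 (beyond the scatter).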

Compound 4, a percentage reported as inhibition, at one concentration (the size of the read-out at that concentration, not a potency): 11.1%
Compound 4: the middle estimate sits 28.9 percentage points above what was measured, within the range that was stated.
By their numbers in this assay, from the lowest: compounds 3, 1 and 4 (each within the scatter of the next, the first and the last beyond it); then compound 2.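

In this assay there is a number 57.3 percentage points lower from compound 2 to compound 4 (beyond the scatter) when only the place of the methoxy group on the phenyl ring changes, so carrying a methoxyphenyl ring at this aromatic carbon is not enough to give the inhibition seen with compound 2. The 2-methoxyphenyl ring lands much closer to the other groups: there is a number 10.7 percentage points higher from compound 3 to compound 4 (beyond the scatter) as a modest step, and a number 3 percentage points higher from compound 1 to compound 4 (within the scatter) so that bromo and 2-methoxyphenyl cannot be told apart here. No measurement is available to explain why the place of the methoxy group matters so much.

Going by these compounds, it remains open whether a 3-methoxyphenyl, 4-hydroxyphenyl or 4-aminophenyl ring would keep the inhibition of compound 2. A plain phenyl ring would show how much of that inhibition depends on the methoxy group itself.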